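A few compounds are considered here, and "the series" means these few. Any claim that something is new, unique, unknown or untested is made for them only; others in the source may bear on it.

In an assay on Sf9 cells for inhibition of protein deacetylase HDAC6 (Homo sapiens), read by fluorescence, with a stated time of 40 min, tested at 100 nM (a lower number here means less inhibition, a higher number more inhibition at the concentration tested (going by the name of the read-out)), the three measured compounds gave these numbers:
compound 1 `COc1ccc(-n2nc(-c3ccccc3)nc2CNc2ccc(C(=O)NO)cc2)cc1` gives 63.4%
compound 2 `COc1ccc(-c2nc(CNc3ccc(C(=O)NO)cc3)n(-c3ccccc3)n2)cc1` gives 77.6%
compound 3 `Cc1ccc(-n2nc(-c3ccccc3)nc2CNc2ccc(C(=O)NO)cc2)cc1` gives 60.7%

Compound 3 has the smallest of the three numbers, but the step of a number 2.7 percentage points lower from compound 1 to compound 3 (within the scatter) is a small one, while the number of compound 2 is well above it. Compound 4 `O=C(NO)c1ccc(NCc2nc(-c3ccccc3)nn2-c2cccc(Cl)c2)cc1` is not yet measured. Its change from compound 3 is 3-chlorophenyl in place of 4-methylphenyl on an aromatic nitrogen. Among the compounds with values here, the only measured step touching this aryl group, a number 2.7 percentage points lower from compound 1 to compound 3 (within the scatter), hardly moved the number; a chlorine on that ring has no measured counterpart. In this assay no step beyond the scatter is therefore expected, and compound 4 is estimated at 62%, with a range from 48% to 76%, meaning an expected step of a number 1.3 percentage points higher from compound 3 to compound 4 (within the scatter).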

Compound 4, a percentage reported as inhibition, at one concentration (the size of the read-out at that concentration, not a potency): 62.3%
Estimate against measurement, compound 4: 0.3 percentage points below; low and high end bracket the measured number.
By their numbers in this assay, from the lowest: compounds 3, 4 and 1 (each within the scatter of the next); then compound 2.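

Replacing 4-methylphenyl with 3-chlorophenyl on the aromatic nitrogen gives a number 1.6 percentage points higher from compound 3 to compound 4 (within the scatter), and replacing 4-methoxyphenyl with it gives a number 1.1 percentage points lower from compound 1 to compound 4 (within the scatter). In this assay, this position therefore takes a ring with a chlorine as well as the two earlier rings, and all three numbers lie within the scatter of each other. No measurement here explains this result.

From the compounds shown here alone, what a 3-aminophenyl or a phenyl ring carrying a carboxylic acid would give on this nitrogen remains open. So does whether 4-chlorophenyl would give a number like that of 3-chlorophenyl.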